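Oxetane Side-Chain Rearrangement and Expected Cytotoxicity

This account rests on a few compounds, and the source may have more. Where it says the series, first, only, none or still open, it means among the compounds named here.

In an ADME assay on HEp-2 cells (Homo sapiens) for cytotoxicity, read by CCK-8 assay, with a stated time of 5 days (on this read-out lower numbers stand for higher toxicity in this test and higher numbers for lower toxicity in this test), compound 1 `Cc1ccc2nc(N3CCCc4ccc(F)cc4C3)cc(NCC3(N)COC3)c2c1` reaches only a limit, > 100000 nM. Compound 2 `NCC(O)CNc1cc(N2CCc3ccccc3C2)nc2ccccc12` gives 21000 nM in this assay, and compound 3 `NCC(O)CNc1cc(N2CCCc3ccccc3C2)nc2ccccc12` gives 21000 nM. Compound 1 thus stands apart, since the limit of > 100000 nM in this assay, at which 1 of the 3 values shown sits, describes its result, while the other two compounds sit at measured numbers. Compound 4 `Cc1ccc2nc(N3CCCc4ccc(F)cc4C3)cc(NC3(CN)COC3)c2c1` differs from compound 1 only in how the same atoms are joined: 3-(aminomethyl)oxetan-3-yl in place of (3-aminooxetan-3-yl)methyl on a nitrogen on an aromatic ring. Among the compounds with values here, no measured step between compounds separated by a single change is available, so the expectation for this assay rests on compound 1 alone. The step from compound 1 to compound 4 is expected to be a number no higher from compound 1 to compound 4 (the limit leaves the size open), with no change beyond the usual scatter. Compound 4 is therefore estimated at 100000 nM, between 30000 nM and 300000 nM, most likely again reported only as a limit.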

Compound 4, half-maximal cytotoxic concentration in the HEp-2 assay: 86000 nM
For compound 4 the middle estimate is 1.2-fold (0.07 log units) above the measured one, and the stated range covers the measured number.
By their numbers in the HEp-2 assay, from the lowest: compounds 2 and 3 (each within the scatter of the next); then compound 4. At a limit, above all of these: compound 1.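

In the HEp-2 assay, placing 3-(aminomethyl)oxetan-3-yl in place of (3-aminooxetan-3-yl)methyl on a nitrogen on an aromatic ring gives an at least 1.1-fold lower number from compound 1 to compound 4 (0.06 log units; that floor lies within the scatter), the first step readable at this position. As far as these compounds go, its true size stays unknown, as compound 1 is held at a limit: the limit of > 100000 nM in the HEp-2 assay, at which 1 of the 4 values shown sits.

In a physicochemical assay for solubility (on this read-out lower numbers stand for lower solubility and higher numbers for higher solubility), compound 1 gives 482 ug/mL. In the physicochemical assay compound 4 gives > 480 ug/mL, which is a limit, so the step in that assay cannot be read.

The compounds shown leave open how a longer chain carrying the amine, or a carboxylic acid in place of the amine, would read in the HEp-2 assay.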